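A few compounds are considered here, and "the series" means these few. Any claim that something is new, unique, unknown or untested is made for them only; others in the source may bear on it.

Measured compounds:
- Compound 1 `CCN1CCN(c2cccc3c2CN([C@H](CCCNC(=O)c2c(C)n[nH]c2C)c2ccc(OC)c(OC)c2)C3=O)CC1`: 16 nM
- Compound 2 `COc1ccc([C@@H](CCCN(C)S(=O)(=O)c2cccs2)N2Cc3c(cccc3N3CCN(C4CCC4)CC3)C2=O)cc1OC`: 4 nM
- Compound 3 `COc1ccc([C@@H](CCCN(C)S(=O)(=O)c2cccs2)N2Cc3c(cccc3N3CCN(C4CC4)CC3)C2=O)cc1OC`: 13 nM

In a functional assay on CHO-K1 cells for antagonist activity at Urotensin-2 receptor (Rattus norvegicus), read by FLIPR and calcium flux, with a stated time of 1 h (a lower number here means a stronger inhibitor, a higher number a weaker inhibitor), compound 1 gives the highest of the three numbers. Compound 3 sits within the scatter of it, while compound 2 lies beyond, with a lower number. For the measured compounds named here, the one measured step, a 3.3-fold higher number from compound 2 to compound 3 (0.51 log units; beyond the scatter), concerns the group on the piperazine nitrogen and leaves the side chain untouched.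

Compound 4 `CCN1CCN(c2cccc3c2CN([C@H](CCCNCc2cccs2)c2ccc(OC)c(OC)c2)C3=O)CC1` differs from compound 1 in that side chain: (thiophen-2-yl)methyl in place of (3,5-dimethyl-1H-pyrazol-4-yl)carbonyl on an amine nitrogen. The amide of compound 1 becomes a simple amine carrying a thiophene. Going by the values given here, no measured step touches this part of the molecule. Compounds 2 and 3 carry a sulfonamide on the same chain nitrogen and both give low numbers, but their cores differ from compound 1 in the piperazine group, so they do not isolate the chain change.

With nothing bearing directly on the change, compound 4 is expected to stay near compound 1, an expected step of a 1.3-fold higher number from compound 1 to compound 4 (0.10 log units; within the scatter), giving an estimate of 20 nM with a range from 5 nM to 80 nM.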

Compound 4, half-maximal inhibitory concentration: 6 nM
Compound 4: middle estimate off by 3.3-fold (0.52 log units), on the high side; measured number inside the range.
By their numbers in this assay, from the lowest: compounds 2 and 4 (each within the scatter of the next); then compounds 3 and 1 (each within the scatter of the next).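

In this assay, the side-chain nitrogen of compound 1 proves open to a large change: a 2.7-fold lower number from compound 1 to compound 4 (0.43 log units; beyond the scatter) comes with (thiophen-2-yl)methyl in place of (3,5-dimethyl-1H-pyrazol-4-yl)carbonyl. For the compounds shown here, this is the first measured step at this position, and it shows that, on this core, neither the carbonyl nor the pyrazole ring is required for a number this low, and that the smaller group of the two gives the lower number. Nothing measured here explains the step.

On these data alone, the change replaces the carbonyl and the ring together, so the share of each in the step stays open. A (thiophen-2-yl)carbonyl group or a (3,5-dimethyl-1H-pyrazol-4-yl)methyl group on the same nitrogen would separate the two.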